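The source may hold more compounds than are shown below. What is called first, only, known or untested is meant among the compounds shown, and "the series" means these compounds.

Working notes on the series.

The shared core is carried by compound 1 `CC(C)COc1ccc(-c2cn3c(=O)n(-c4ccccc4)nc3c(N)n2)cc1`, compound 2 `CCCOc1ccc(-c2cn3c(=O)n(-c4ccccc4)nc3c(N)n2)cc1` and compound 3 `COc1ccc(-c2cn3c(=O)n(-c4ccccc4)nc3c(=O)[nH]2)cc1`. In an assay on cells for displacement of a labelled ligand from adenosine receptor A1 (Homo sapiens), read by scintillation counting, with a stated time of 3 h (on this read-out lower numbers stand for stronger inhibition and higher numbers for weaker inhibition), compound 1 has no result, recorded as "not determined" (no result reported). In this assay compound 2 returns only a limit of the assay, > 30000 nM. In this assay compound 3 likewise returns only a limit, > 30000 nM. Compound 2 therefore stands with no single number of its own; its entry is a limit, one further entry is a limit, and one entry carries no number at all, so that the series rests on the limit of > 30000 nM in this assay, at which 2 of the 3 values shown sit, rather than on measured values.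

Compound 4 `Nc1nc(-c2ccc(O)cc2)cn2c(=O)n(-c3ccccc3)nc12` is the next member, still to be measured in this assay. Its difference from compound 2 is hydrogen in place of propyl on an oxygen on an aromatic ring; cut one bond further out, propoxy to hydroxy. Within the data shown here, no step between measured compounds is available, so the size and direction of this change cannot be read from the data; the expectation is no movement beyond the scatter, with compound 4 most likely again at the limit. The step from compound 2 to compound 4 is estimated at a step that the limit leaves unreadable from compound 2 to compound 4. For compound 4 in this assay the estimate is 40000 nM, within 8000 nM to 200000 nM.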

Compound 4, inhibition constant: 45 nM
For compound 4 the middle estimate is 890-fold (2.95 log units) above the measured one; measured number below the stated range.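

In this assay, among these compounds, propoxy to hydroxy gives an at least 660-fold lower number from compound 2 to compound 4 (2.82 log units; beyond the scatter), so the group on this oxygen decides whether the series registers at all, a point that the earlier compounds, with a limit or no result, could not show. Among the compounds shown here, compound 4, at 45 nM, carries the only single number, and it sits on the compound with hydrogen in place of propyl on that oxygen. Compound 2 gives > 30000 nM, which is a limit of the assay, so the step has a minimum size but no exact one: the limit of > 30000 nM in this assay, at which 2 of the 4 values shown sit.

The steps to compound 1 and compound 3 cannot be read, and so the compounds shown do not tell whether the number climbs gradually or abruptly as the chain on the oxygen grows from hydrogen to propyl, with ethoxy being the obvious missing intermediate. They also leave open whether the hydrogen on this oxygen is itself needed, a question that an amine or a carboxylic acid in place of hydroxy on the aromatic ring would address.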